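Adding an acetyl to the ring nitrogen of compound 1

A few compounds are considered here, and "the series" means these few. Any claim that something is new, unique, unknown or untested is made for them only; others in the source may bear on it.

Compound 1 `O=C(Nc1ccccc1C(F)(F)F)C1CCc2ccccc2N1` gives 40400 nM in a functional assay on HCT-15 cells (Homo sapiens) for cytotoxicity, read by sulforhodamine B assay, with a stated time of 72 h (on this read-out higher numbers stand for weaker inhibition of growth and lower numbers for stronger inhibition of growth), the highest number of the three measured compounds. Among the compounds with values here, compound 3 `O=C(Nc1ccccc1O)C1CCc2ccccc2N1` gives 5610 nM, and the single change a 7.2-fold lower number from compound 1 to compound 3 (0.86 log units; beyond the scatter). Compound 2 `CCC(=O)N1c2ccccc2CCC1C(=O)Nc1cc(C(F)(F)F)cc(C(F)(F)F)c1` gives 7620 nM, but it differs from compound 1 in two places, so its lower number cannot be tied to one change. Compound 4 `CC(=O)N1c2ccccc2CCC1C(=O)Nc1ccccc1C(F)(F)F` carries acetyl in place of hydrogen on a nitrogen on an aromatic ring in a ring. No measured step changes only this position, so nothing shown bears directly on it; compound 2, which also bears an acyl group on that nitrogen, merely hints that a lower number is possible. The expected step of a 2.0-fold lower number from compound 1 to compound 4 (0.31 log units; beyond the scatter) is therefore modest, and compound 4 is estimated at 20000 nM, between 6000 nM and 60000 nM.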

Compound 4, concentration for 50% growth inhibition: > 80000 nM
Compound 4: a limit, no number; the forecaster's own chance of this, stated with the estimate: 10%; middle value at least 4.0-fold (0.60 log units) away from the limit.
By their numbers in this assay, from the lowest: compounds 3 and 2 (each within the scatter of the next); then compound 1. At a limit, above all of these: compound 4.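

In this assay compound 4 gives > 80000 nM, which is a limit and not a number. Within the data shown here, this is the first direct reading at this position, and the step is an at least 1.9-fold higher number from compound 1 to compound 4 (0.29 log units; that floor lies within the scatter). Acetyl on the ring nitrogen therefore brings no lower number to the core of compound 1, so the hint from compound 2 does not hold for this change.

As far as these compounds go, how far the true value of compound 4 lies from that of compound 1 stays open. So does whether a methyl or an amine on this nitrogen would give a lower number.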